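A few compounds are considered here, and "the series" means these few. Any claim that something is new, unique, unknown or untested is made for them only; others in the source may bear on it.

Going by the values given here, compound 1, `COc1cc(-c2nnc3n2NC(c2cccs2)C(C(=O)c2ccc(C)cc2)S3)cc(OC)c1OC`, is the only member of this small set that returns a numbered potency. In a functional assay on A549 cells (Homo sapiens) for cytotoxicity, read by MTT assay, with a stated time of 48 h (on this read-out lower numbers stand for stronger inhibition and higher numbers for weaker inhibition), compound 1 gives 12700 nM. Compound 2, `COc1cc(-c2nnc3n2NC(c2ccco2)C(C(=O)C2CC2)S3)cc(OC)c1OC`, differs from it in more than one place. Compound 2 gives only > 100000 nM in this assay, a limit of the measurement rather than a number, and it is the limit of > 100000 nM in this assay, at which 1 of the 2 values shown sits. Among the compounds with values here, with no single-change step between the measured pair, the step to compound 3 has no direct precedent here.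

Compound 3, `COc1ccc(C(=O)C2Sc3nnc(-c4cc(OC)c(OC)c(OC)c4)n3NC2c2cccs2)cc1`, differs from compound 1 by one change, (methoxy in place of methyl on an aromatic carbon), which on the wider reading is 4-methylphenyl to 4-methoxyphenyl. The step from compound 1 to compound 3 is expected to be a 1.1-fold lower number from compound 1 to compound 3 (0.02 log units; within the scatter), that is, no shift beyond the usual scatter in either direction. Compound 3 is therefore estimated at 12000 nM in this assay. The plausible range for compound 3 is expected to run from 4000 nM to 40000 nM.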

Compound 3, half-maximal inhibitory concentration: > 100000 nM
Compound 3 ended at the assay's limit; the forecaster's own chance of this, stated with the estimate: 10%; middle value at least 8.3-fold (0.92 log units) away from the limit.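

In this assay, going by these compounds alone, the one change from 4-methylphenyl to 4-methoxyphenyl gives an at least 7.8-fold higher number from compound 1 to compound 3 (0.89 log units; beyond the scatter), the first single-change comparison in this set. It shows that this place on the six-membered aromatic ring, para to a large group, is not indifferent to the swap: methoxy in place of methyl is enough to lose the numbered potency of compound 1. Compound 3 gives > 100000 nM, which is a limit and not a number, so the true size of the step stays unknown, and only one compound in the set still has a numbered value: the limit of > 100000 nM in this assay, at which 2 of the 3 values shown sit.

On these data alone, whether an ethyl group, a chlorine atom or an amine at this place would keep a numbered potency remains open. Also open, as far as these compounds go, is how much each of the several differences in compound 2 contributes to its result.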